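This account rests on a few compounds, and the source may have more. Where it says the series, first, only, none or still open, it means among the compounds named here.

Going by the values given here, in an ADME assay on HEK293 cells (Homo sapiens) for cytotoxicity, read by ATP content, with a stated time of 6 h (a higher number here means that more compound is tolerated, a lower number that less compound is tolerated), the series so far offers limits and no numbers. Compound 1 `CCCCNc1nc(N)nc2ccn(CCCc3ccccc3)c12` gives > 24000 nM, which is a limit. Compound 2 `CCCCNc1nc(N)nc2ccn(Cc3ncccc3OC)c12` gives > 24000 nM, also a limit, so no number is known for compound 2. Among the compounds with values here, the one measured step, a step that the two limits leave unreadable from compound 1 to compound 2, therefore has no size to carry forward. The record for compound 1 and compound 2 comes down to the limit of > 24000 nM in this assay, at which 2 of the 2 values shown sit.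

Compound 3 `COc1cccnc1Cn1ccc2nc(N)nc(OCc3ncc(C)o3)c21` keeps the 3-methoxypyridin-2-yl group of compound 2 and differs as follows: (5-methyl-1,3-oxazol-2-yl)methoxy in place of butylamino on an aromatic carbon. (5-methyl-1,3-oxazol-2-yl)methoxy stands in place of butylamino on an aromatic carbon. Within the data shown here, compound 1 and compound 2 both carry butylamino there, so no measured step covers this change.

With compound 2 reported only as the limit > 24000 nM, no step beyond the scatter is expected in this assay, and no direction can be assigned. The estimated step is a number no higher from compound 2 to compound 3 (the limit leaves the size open). For compound 3 the expected value is 24000 nM, with an estimated range from 10000 nM to 48000 nM.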

Compound 3, half-maximal cytotoxic concentration: > 24000 nM
Compound 3: a limit, no number; the forecaster's own chance of this, stated with the estimate: 75%; the middle value lies on the limit itself.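

No step can be read from compound 2 to compound 3 in this assay, since both values are limits, and the record comes down to one entry: the limit of > 24000 nM in this assay, at which 3 of the 3 values shown sit. The compounds shown leave open the half-maximal cytotoxic concentration of each compound, and whether (5-methyl-1,3-oxazol-2-yl)methoxy in place of butylamino shifts it at all.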